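Aryl sulfonamide piperidine series: trifluoromethyl to fluoro swap

The source may hold more compounds than are shown below. What is called first, only, known or untested is meant among the compounds shown, and "the series" means these compounds.

Compound 1 `CC1CCN(C2CCN(S(=O)(=O)c3cccc(-c4ccccc4C(F)(F)F)c3)CC2)CC1` is the reference point of this set. Among the measured compounds shown here, in a functional assay on DLD-1 cells (Homo sapiens) for antiproliferative activity, read by CellTiter-Glo, with a stated time of 72 h (a lower number here means a stronger inhibitor, a higher number a weaker inhibitor), compound 1 gives 10 nM, the only reading among the three that is a number rather than a limit. Compound 2 `CC1CCN(C2CCN(S(=O)(=O)c3ccc(C(C)(C)C)cc3)CC2)CC1` carries a tert-butyl-substituted aryl sulfonamide on the shared core; in this assay compound 2 reports > 5000 nM, which is a limit of the assay and not a number. Compound 3 `Cc1cc(C)c(S(=O)(=O)N2CCC(C3OCC(C)CO3)CC2)c(C)c1`, built on a different core, reports > 5000 nM in this assay, again a limit. For the measured compounds named here, no pair among the measured compounds differs in a single place, so no measured step is available; what the numbers show is that compound 1 stands apart from the two limits, (the limit of > 5000 nM in this assay, at which 2 of the 3 values shown sit).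

The next compound, compound 4 `CC1CCN(C2CCN(S(=O)(=O)c3cccc(-c4ccc(F)cc4)c3)CC2)CC1`, keeps the core and the sulfonamide of compound 1 and alters the pendant aryl: 4-fluorophenyl in place of 2-(trifluoromethyl)phenyl on an aromatic carbon. The biaryl arrangement present in compound 1 and absent in compound 2 is retained. The expected step of a 3.0-fold higher number from compound 1 to compound 4 (0.48 log units; beyond the scatter) is a modest loss of potency, near the edge of the scatter. Compound 4 is estimated at 30 nM, with a range from 8 nM to 150 nM.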

Compound 4, half-maximal inhibitory concentration: 12 nM
Compound 4: middle estimate off by 2.5-fold (0.40 log units), on the high side; the range from low to high includes it.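

In this assay, among the compounds shown here, the first measured step at this position, 4-fluorophenyl in place of 2-(trifluoromethyl)phenyl on an aromatic carbon, gives a 1.2-fold higher number from compound 1 to compound 4 (0.08 log units; within the scatter). The earlier compounds shown here offered no single-place comparison, and this pair shows that two different pendant aryl groups at this place, one of 10 heavy atoms and one of 7, give readings that cannot be told apart, so the 2-(trifluoromethyl)phenyl group of compound 1 is not required for a low reading in this assay. Nothing measured here gives a reason for this result.

Still open, from the compounds shown here alone, is how far this place accepts other groups: a plain phenyl ring, or an aryl ring carrying an amine or a carboxylic acid, would test whether any substituent on the pendant ring matters at all. Compound 2 and compound 3 differ from compound 4 in more than one place, so the part played by the biaryl arrangement itself remains unresolved by a single-place comparison.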